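A Methyl Added to the Amide of Compound 2

The source may report more compounds than this note shows. Statements on the series, on what has been measured and on what is new or still open speak of the compounds shown alone.

Measured in a physicochemical assay for solubility; on this read-out lower numbers stand for lower solubility and higher numbers for higher solubility (all three values are limits):
- Compound 1 (`CNC(=O)c1cc(C(=O)N[C@H]2[C@@H]3COC[C@@H]32)cc2c1OC[C@H]2c1cccc(OC)c1`): >= 186 ug/mL
- Compound 2 (`CNC(=O)c1cc(C(N)=O)cc2c1OC[C@H]2c1ccccc1`): >= 144 ug/mL
- Compound 3 (`CNC(=O)c1cc(C(N)=O)cc2c1O[C@H](CF)[C@H]2c1ccccc1`): >= 128 ug/mL

Compound 2 stands only at a limit (>= 144 ug/mL), and the other two values are limits as well. Compound 4 (`CNC(=O)c1cc(C(=O)NC)c2c(c1)[C@H](c1ccccc1)CO2`) has not yet been measured. It departs from compound 2 by methyl in place of hydrogen on an amide-type nitrogen (methyl in place of hydrogen on an amide-type nitrogen, or carbamoyl to methylcarbamoyl). For the measured compounds named here, the only measured step, a step that the two limits leave unreadable from compound 2 to compound 3, is a different change, fluoromethyl in place of hydrogen on a saturated ring carbon, and it offers no size to carry over. Compound 1 also carries a substituent on an amide-type nitrogen. Resting on compound 1, whose limit is >= 186 ug/mL, no step beyond the scatter is expected in this assay, in either direction. The expected step is a step that the limit leaves unreadable from compound 2 to compound 4, an estimate only. For compound 4 the estimated solubility is 150 ug/mL, with an expected range from 70 ug/mL to 220 ug/mL.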

Compound 4, solubility: >= 130 ug/mL
Compound 4 was reported as a limit (the forecaster's own chance of this, stated with the estimate: 70%); the middle value does not contradict the limit.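

In this assay compound 2 and compound 4 are both reported only as limits, so no step can be read for methyl in place of hydrogen on an amide-type nitrogen. The compounds shown leave open whether this change alters solubility at all, and in which direction.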